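Aryl Ester Variation on a Shared Core Against Leukemia Cells

The source may hold more compounds than are shown below. What is called first, only, known or untested is meant among the compounds shown, and "the series" means these compounds.

Compound 1 `CC1=CC[C@H](C(C)C)c2cc(C)c(OC(=O)c3ccc(C)cc3)cc21`: 100%
Compound 2 `CC1=CC[C@H](C(C)C)c2cc(C)c(OC(=O)c3ccc([N+](=O)[O-])cc3)cc21`: 89%

Among the compounds with values here, in a functional assay on K562 cells (Homo sapiens) for antiproliferative activity, read by sulforhodamine B assay, with a stated time of 48 h, tested at 50 uM (on this read-out lower numbers stand for less inhibition and higher numbers for more inhibition at the one concentration tested (going by the name of the read-out)), compound 2 holds the lower of the two numbers; its nearest neighbour is compound 1, and the only measured step, a number 11 percentage points lower from compound 1 to compound 2 (beyond the scatter), was modest yet beyond the scatter. Compound 3 `CC1=CC[C@H](C(C)C)c2cc(C)c(OC(=O)c3ccccc3)cc21` differs from compound 2 by hydrogen in place of nitro on an aromatic carbon. Within the data shown here, since removing the nitro group undoes the one change that lowered inhibition, a modest rise is expected, though no direct step for this exchange exists. The expected step is a number 6 percentage points higher from compound 2 to compound 3 (within the scatter). Compound 3 is therefore estimated at 95%, within 82% to 100%.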

Compound 3, a percentage reported as inhibition, at one concentration (the size of the read-out at that concentration, not a potency): "not active" (no number reported)
The entry for compound 3 holds no number; there is nothing to compare the estimate with.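

Within the data shown here, compound 3 is recorded in this assay as "not active", without a number, so no step from compound 2 to compound 3 can be read. As far as these compounds go, how the change from 4-nitrophenyl to phenyl shifts inhibition stays open, and no evidence at hand bears on this result.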